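A few compounds are considered here, and "the series" means these few. Any claim that something is new, unique, unknown or untested is made for them only; others in the source may bear on it.

Compound 1 `O=C(O)c1csc(-n2nc(-c3ccccc3)c3ccc(F)cc32)n1` and compound 2 `O=C(O)c1csc(-n2nc(-c3ccccc3)c3ccc(O)cc32)n1` share one core and differ in a single group on an aromatic ring. In an assay on isolated protein for antagonist activity at prostaglandin E2 receptor EP1 subtype (Homo sapiens), read by reporter gene assay (on this read-out lower numbers stand for stronger inhibition and higher numbers for weaker inhibition), compound 1 gives 2 nM, while compound 2 gives 140 nM, the higher of the two numbers shown. The step of a 70-fold higher number from compound 1 to compound 2 (1.85 log units; beyond the scatter) is large. Compound 3 `COc1ccc2c(-c3ccccc3)nn(-c3nc(C(=O)O)cs3)c2c1` is compound 2 with methyl in place of hydrogen on an oxygen on an aromatic ring. Among the compounds with values here, no measured pair shows a hydroxy capped in this way, so the only step at hand, fluoro to hydroxy, gives little guidance on direction. Compound 3 is therefore expected to give about 80 nM, between 15 nM and 400 nM. That expected step, a 1.8-fold lower number from compound 2 to compound 3 (0.24 log units; within the scatter), has no clear direction beyond the scatter.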

Compound 3, half-maximal inhibitory concentration: 1.1 nM
Beside the measured number, compound 3's estimate is 73-fold (1.86 log units) above it; the measured number lies below the stated range.
By their numbers in this assay, from the lowest: compounds 3 and 1 (each within the scatter of the next); then compound 2.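

Placing methyl on this oxygen gives a 130-fold lower number from compound 2 to compound 3 (2.10 log units; beyond the scatter), so the large rise seen with hydroxy does not carry over to methoxy. Methoxy and fluoro cannot be told apart at this position, with a 1.8-fold lower number from compound 1 to compound 3 (0.26 log units; within the scatter), which leaves hydroxy as the only one of the three groups that stands apart. A change of just one heavy atom is therefore enough to produce a large step here.

Going by these compounds, whether a longer chain on this oxygen, such as ethoxy, or an amine on the same aromatic carbon would fit with methoxy and fluoro or with hydroxy stays open. Nothing available gives a measured reason for the gap between hydroxy and methoxy.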